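The source may hold more compounds than are shown below. What is called first, only, known or untested is meant among the compounds shown, and "the series" means these compounds.

Compound 1 `Cc1nn(C)c2c1C(c1ccccc1)=NCCN2C` is the starting point of this account. In a functional assay on the whole organism for positive allosteric modulation, with Rattus norvegicus as the target (on this read-out higher numbers stand for an effect only at larger amounts of compound and lower numbers for an effect already at smaller amounts), compound 1 gives 2.5 mg/kg, level with compound 3 at the digits shown. Compound 3 `Cc1nn(C)c2c1C(c1ccccc1Cl)=NCCN2C` carries chloro in place of hydrogen on an aromatic carbon and gives 2.5 mg/kg in this assay; the step shows no change at the digits printed from compound 1 to compound 3 (within the scatter). Compound 2 `Cc1nn(C)c2c1C(c1ccccc1)=NCCN2CCCN(C)C` carries 2-(dimethylamino)ethyl in place of hydrogen on a saturated chain carbon bound to a nitrogen on an aromatic ring in a ring. For compound 2 this assay reports only a limit, > 10 mg/kg, so that the step from compound 1 is an at least 4.0-fold higher number from compound 1 to compound 2 (0.60 log units; beyond the scatter), with the limit of > 10 mg/kg in this assay, at which 1 of the 3 values shown sits, marking the limit at which the value sits.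

Compound 4 `Cc1nn(C)c2c1C(c1ccc(O)cc1)=NCCN2C` is not yet measured. It differs from compound 1 by hydroxy in place of hydrogen on an aromatic carbon. Among the measured compounds shown here, of the measured steps, only the one from compound 1 to compound 3 also alters an aromatic carbon of the same ring, and that step stayed within the scatter; the step from compound 1 to compound 2 concerns a different part of the core and does not bear on this change. He therefore expects the step of no change at the digits printed from compound 1 to compound 4 (within the scatter) to lie within the scatter. For compound 4 the value in this assay is estimated at 2.5 mg/kg, within a range from 1.2 mg/kg to 6 mg/kg.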

Compound 4, minimum effective dose: 2.5 mg/kg
Estimate against measurement, compound 4: no gap at the digits printed; the range from low to high includes it.
By their numbers in this assay, from the lowest: compounds 1, 3 and 4 (each within the scatter of the next). At a limit, above all of these: compound 2.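

In this assay, hydroxy on an aromatic carbon para to a large group gives no change at the digits printed from compound 1 to compound 4 (within the scatter). The earlier compounds shown here showed such a flat step on this six-membered aromatic ring for chloro only; hydroxy, with 1 hydrogen-bond donor and 1 hydrogen-bond acceptor, now leaves the read-out equally unmoved, so this place on the ring accepts both this change and the earlier one without a step beyond the scatter. No measurement shown here gives a reason for this flat result.

From the compounds shown here alone, whether this holds for other groups at the same place, such as an amine, a carboxylic acid or a methoxy group, remains open, since two substituents on one ring say nothing about larger or charged ones. In this assay, going by these compounds, compound 2 gives > 10 mg/kg, which is a limit and not a number, and what a shorter chain such as ethyl would do on that ring nitrogen also stays open.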